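This account rests on a few compounds, and the source may have more. Where it says the series, first, only, none or still open, it means among the compounds named here.

Measured compounds in an assay on HEK293 cells for inhibition of solute carrier family 22 member 12 (Homo sapiens); a lower number here means a stronger inhibitor, a higher number a weaker inhibitor:
- compound 1 `O=S(=O)(CSc1nnc(Br)n1Cc1ccc(Br)c2ccccc12)Nc1ccc(Cl)nc1`: 1940 nM
- compound 2 `O=S(=O)(CSc1nnc(Br)n1Cc1ccc(Br)c2ccccc12)Nc1ccc(F)nc1`: 1550 nM
- compound 3 `O=S(=O)(CSc1nnc(Br)n1Cc1ccc(Br)c2ccccc12)Nc1ccc(Cl)nc1Cl`: 1660 nM

All three share the same core and differ only in the substitution of the pyridine ring on the sulfonamide nitrogen. Compound 1 gives the highest of the three numbers in this assay, but its nearest neighbour compound 3 sits at a 1.2-fold lower number from compound 1 to compound 3 (0.07 log units; within the scatter) and compound 2 at a 1.3-fold lower number from compound 1 to compound 2 (0.10 log units; within the scatter), so the three values cannot be ranked against each other. The remaining step, a 1.1-fold higher number from compound 2 to compound 3 (0.03 log units; within the scatter), confirms that the substitution pattern on this ring has not moved the number beyond the scatter anywhere in the set.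

Compound 4 `O=S(=O)(CSc1nnc(Br)n1Cc1ccc(Br)c2ccccc12)Nc1ccc(Br)nc1` is the next member and is to be measured in this assay. It differs from compound 1 as follows: bromo in place of chloro on an aromatic carbon. The step that bears on it most directly is a 1.3-fold lower number from compound 1 to compound 2 (0.10 log units; within the scatter), a halogen exchange on the same aromatic carbon next to the ring nitrogen, which stayed within the scatter. With no change in heavy-atom count, ring, donors, acceptors or charge, the exchange to bromo is expected to behave in the same way. The expected step is therefore a 1.1-fold lower number from compound 1 to compound 4 (0.03 log units; within the scatter), none beyond the scatter. Compound 4 is estimated at 1800 nM, with a range of 900 nM to 3600 nM.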

Compound 4, half-maximal inhibitory concentration: 2200 nM
Compound 4: the middle estimate sits 1.2-fold (0.09 log units) below what was measured, and the stated range covers the measured number.
By their numbers in this assay, from the lowest: compounds 2, 3, 1 and 4 (each within the scatter of the next).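

In this assay, bromo in place of chloro on the aromatic carbon next to the ring nitrogen gives a 1.1-fold higher number from compound 1 to compound 4 (0.05 log units; within the scatter), and bromo in place of fluoro on that same carbon gives a 1.4-fold higher number from compound 2 to compound 4 (0.15 log units; within the scatter), so the position has now carried fluoro, chloro and bromo with no step beyond the scatter. The step from the 2,6-dichloropyridin-3-yl group to the 6-bromopyridin-3-yl group, a 1.3-fold higher number from compound 3 to compound 4 (0.12 log units; within the scatter), also stays within the scatter, and the four values therefore remain a single unranked group, with the halogen exchanges shown giving no handle on this read-out. No measurement on hand bears on why these halogen exchanges leave the number within the scatter.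

The compounds shown carry only halogens at this position, so it remains open whether hydrogen, an amine, a methoxy group or a carboxylic acid on this carbon would give a step beyond the scatter. From the compounds shown here alone, it is also open whether the shared core outside the pyridine ring responds as little to change, since every compound here holds that part constant.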